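Aryl swap from compound 3 to compound 4

The source may hold more compounds than are shown below. What is called first, only, known or untested is meant among the compounds shown, and "the series" means these compounds.

Measured in a functional assay on Jurkat cells (Homo sapiens); on this read-out lower numbers stand for stronger inhibition and higher numbers for weaker inhibition:
- compound 1 `CC(C)[C@H](NC(=O)COc1cccc2ccccc12)C(=O)N[C@@H](CC(=O)O)C(=O)COc1cccc2ccccc12` limit of > 100000 nM
- compound 2 `CC(C)[C@H](NC(=O)COc1cccc2ccccc12)C(=O)N[C@@H](CC(=O)O)C(=O)COc1ccc2ccccc2c1` limit of > 100000 nM
- compound 3 `CC(C)[C@H](NC(=O)COc1cccc2ccccc12)C(=O)N[C@@H](CC(=O)O)C(=O)COc1ccc(OC(F)(F)F)cc1` value of 29100 nM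

The entries for compound 1 and compound 2 are not numbers but (the limit of > 100000 nM in this assay, at which 2 of the 3 values shown sit). Among the measured compounds shown here, compound 3 holds the only number, at 29100 nM. For the measured compounds named here, the steps that bear on the change are an at least 3.4-fold lower number from compound 1 to compound 3 (0.53 log units; beyond the scatter) and an at least 3.4-fold lower number from compound 2 to compound 3 (0.53 log units; beyond the scatter). Both concern the same place, but neither involves the entering group.

Compound 4 `CC(C)[C@H](NC(=O)COc1cccc2ccccc12)C(=O)N[C@@H](CC(=O)O)C(=O)COc1ccccc1[N+](=O)[O-]` carries 2-nitrophenyl in place of 4-(trifluoromethoxy)phenyl on an oxygen on a saturated carbon. Every measured replacement of the 4-(trifluoromethoxy)phenyl group of compound 3 reads at the limit, so a modest rise in this assay is expected. The estimated step is a 1.5-fold higher number from compound 3 to compound 4 (0.19 log units; within the scatter). The estimate for compound 4 is 45000 nM, with an expected range of 12000 nM to 100000 nM.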

Compound 4, half-maximal inhibitory concentration: > 100000 nM
Compound 4 gave a limit, no number (the forecaster's own chance of this, stated with the estimate: 35%); at least 2.2-fold (0.34 log units) between middle value and limit.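

In this assay, the change to 2-nitrophenyl gives an at least 3.4-fold higher number from compound 3 to compound 4 (0.53 log units; beyond the scatter), which shows that a single six-membered aromatic ring on this oxygen does not by itself keep a measurable number. Of the aryl groups shown here, only 4-(trifluoromethoxy)phenyl gives one. Compound 4 reads as a limit, not a number: the limit of > 100000 nM in this assay, at which 3 of the 4 values shown sit.

The steps from compound 1 and compound 2 to compound 4 join limit to limit and cannot be read. The change from compound 3 to compound 4 alters both the substituent and its place on the ring, and the compounds shown cannot separate the two; 4-nitrophenyl or 2-(trifluoromethoxy)phenyl would bear on this.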